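The source may report more compounds than this note shows. Statements on the series, on what has been measured and on what is new or still open speak of the compounds shown alone.

Measured so far:
Compound 1, `CC(C)CN1CCN(c2ccc3c(c2)oc(=O)n3C(=O)NCCCCc2ccccc2)CC1` — in an assay on HEK293 cells for inhibition of acid ceramidase (Homo sapiens), read by fluorescence, with stated times of 10 min and 3 h (a lower number here means a stronger inhibitor, a higher number a weaker inhibitor), compound 1 gives 127 nM.
Compound 2, `CN1CCC(c2ccc3c(c2)oc(=O)n3C(=O)NCCCCc2ccccc2)CC1` — in this assay compound 2 gives 129 nM.

Compound 2 has the highest of the two numbers, but its nearest neighbour is compound 1, and the step of a 1.0-fold higher number from compound 1 to compound 2 (0.01 log units; within the scatter) lies within the scatter, so the two cannot be ordered. Compound 3, `CN1CCN(c2ccc3c(c2)oc(=O)n3C(=O)NCCCCc2ccccc2)CC1=O`, is the next compound to be measured. It differs from compound 2 in one place: 4-methyl-3-oxopiperazin-1-yl in place of 1-methylpiperidin-4-yl on an aromatic carbon. Within the data shown here, only one measured step bears on this change, a 1.0-fold higher number from compound 1 to compound 2 (0.01 log units; within the scatter), which shows that exchanging one ring amine for another at this aromatic carbon left the number essentially unchanged. On that basis no step beyond the scatter is expected from compound 2 to compound 3 in this assay, with the estimated step being a 1.2-fold higher number from compound 2 to compound 3 (0.07 log units; within the scatter). Compound 3 is therefore expected to give about 150 nM, most likely between 70 nM and 350 nM.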

Compound 3, half-maximal inhibitory concentration in the acid ceramidase assay: 92 nM
Estimate against measurement, compound 3: 1.6-fold (0.21 log units) above, and the stated range covers the measured number.
By their numbers in the acid ceramidase assay, from the lowest: compounds 3, 1 and 2 (each within the scatter of the next).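

Across the ring groups now shown at this aromatic carbon, including the 4-methyl-3-oxopiperazin-1-yl group, the acid ceramidase assay gives no step beyond the scatter (a 1.4-fold lower number from compound 2 to compound 3 (0.15 log units; within the scatter)) and (a 1.4-fold lower number from compound 1 to compound 3 (0.14 log units; within the scatter)). The same exchange does matter in a physicochemical assay for solubility, read by HPLC, in phosphate buffer, measured as kinetic solubility, with a stated time of 1 h, at pH 7.4, tested at 250 uM (a higher number here means a more soluble compound, a lower number a less soluble compound), where compound 3 is far less soluble than compound 2: the measured solubility of compound 2, 120000 nM, and of compound 3, < 1000 nM, an at least 120-fold lower number (2.07 log units; beyond the scatter). In the physicochemical assay compound 2 gives 120000 nM. In the physicochemical assay the value of compound 3, < 1000 nM, is a limit of the assay and not a number: the limit of < 1000 nM in the physicochemical assay, at which 1 of the 2 values shown sits.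

The entering group brings both another ring nitrogen and a carbonyl, and the compounds shown do not separate which of the two goes with the drop in solubility. Also open, from the compounds shown here alone, is how a carboxylic acid or a primary amine on this ring group, or a longer chain in place of its methyl, would read in the acid ceramidase assay and the physicochemical assay.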